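A few compounds are considered here, and "the series" means these few. Any claim that something is new, unique, unknown or untested is made for them only; others in the source may bear on it.

Compound 1 `CCN(CC)CCNc1nc(-c2ccc(NC(=O)Nc3ccc(Cl)cc3)cc2)nc2ccsc12` and compound 2 `CCN(CC)CCNc1nc(-c2ccc(NC(=O)Nc3ccccc3Cl)cc2)nc2ccsc12` share one core and differ only in the chlorophenyl on the amide-type nitrogen. In a functional assay on HT-29 cells (Homo sapiens) for cytotoxicity, read by MTT assay, with a stated time of 72 h (a lower number here means a stronger inhibitor, a higher number a weaker inhibitor), compound 1 gives 150 nM, and compound 2 gives 620 nM. The single measured step, a 4.1-fold higher number from compound 1 to compound 2 (0.62 log units; beyond the scatter), leaves compound 2 with the higher of the two numbers shown. Compound 3 `CCN(CC)CCNc1nc(-c2ccc(NC(=O)Nc3ccc(Cl)cc3Cl)cc2)nc2ccsc12` differs from compound 2 by chloro in place of hydrogen on an aromatic carbon, so that the group on the amide-type nitrogen goes from 2-chlorophenyl to 2,4-dichlorophenyl. Within the data shown here, only the step from compound 1 to compound 2 bears on this: the compound carrying chloro solely at the aromatic carbon that compound 3 now gains had the lower number, while no pair shows what the two chlorines do together. A partial reversal of that step is expected rather than a full one. Compound 3 is therefore estimated to shift by a 2.1-fold lower number from compound 2 to compound 3 (0.32 log units; beyond the scatter). The estimate for compound 3 in this assay is 300 nM, with a range from 100 nM to 900 nM.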

Compound 3, half-maximal inhibitory concentration: 1940 nM
For compound 3 the middle estimate is 6.5-fold (0.81 log units) below the measured one; measured number outside the range, above it.
By their numbers in this assay, from the lowest: compound 1; then compound 2; then compound 3.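

In this assay, among these compounds, adding chloro to the 2-chlorophenyl group does not move the number towards that of compound 1, as the single pair had suggested; the change to 2,4-dichlorophenyl instead gives a 3.1-fold higher number from compound 2 to compound 3 (0.50 log units; beyond the scatter). Read from the other side, the same kind of change on the 4-chlorophenyl group gives a 13-fold higher number from compound 1 to compound 3 (1.11 log units; beyond the scatter), the only large step among the three shown, so compound 3 carries a higher number than either compound with a single chloro, and the effect of each chlorine on this number depends on whether the other is present. Nothing available here accounts for this behaviour of the two chlorines together.

The compounds shown leave open whether the rise belongs to chlorine itself or would also follow a fluoro, a methyl or a methoxy group entering at the same aromatic carbon, and how an unsubstituted phenyl on the amide-type nitrogen would compare with all three. They also leave open whether the same order would hold with the diethylamino group of the side chain replaced by a morpholine.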